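An Amino-to-Nitro Change Tested on a Second Core

The source may report more compounds than this note shows. Statements on the series, on what has been measured and on what is new or still open speak of the compounds shown alone.

The measured compounds, in a functional assay on HCT-8 cells (Homo sapiens) for antiproliferative activity, read by MTT assay, with a stated time of 48 h; a higher number here means a weaker inhibitor, a lower number a stronger inhibitor:
Compound 1, `COc1ccc2c(/C=C/C(=O)c3cc(N)c(OC)c(OC)c3)c[nH]c2c1`, gives 368 nM.
Compound 2, `COc1ccc2c(/C=C/C(=O)c3cc(OC)c(OC)c([N+](=O)[O-])c3)c[nH]c2c1`, gives 982 nM.
Compound 3, `COc1cc(C(=O)/C=C/c2cn(C)c3ccccc23)cc(N)c1OC`, gives 605 nM.

Compound 1 and compound 2 share a core and differ at one place: nitro in place of amino on an aromatic carbon. That change produced a 2.7-fold higher number from compound 1 to compound 2 (0.43 log units; beyond the scatter). Compound 3 carries the same amino group on the same kind of ring, but on a different core; how the core of compound 3 differs from that of compound 1 is not broken down here. In this assay compound 3 and compound 2 lie within the scatter of each other, as do compound 3 and compound 1, so no order among them can be read from these numbers.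

Compound 4, `COc1cc(C(=O)/C=C/c2cn(C)c3ccccc23)cc([N+](=O)[O-])c1OC`, has not yet been measured. It stands to compound 3 as compound 2 stands to compound 1: nitro in place of amino on an aromatic carbon. The surroundings of the changed carbon are described in the same words for both pairs, so this is the same change on a second core. Going by the values given here, with only one earlier instance of this change, the expectation for compound 4 rests on that single step. Among the compounds with values here, compound 4 is expected to show a 2.6-fold higher number from compound 3 to compound 4 (0.42 log units; beyond the scatter), mirroring the step from compound 1 to compound 2, because a 2.7-fold higher number from compound 1 to compound 2 (0.43 log units; beyond the scatter) is the only guide available. The estimate for compound 4 in this assay is 1600 nM, expected to fall between 700 nM and 4000 nM.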

Compound 4, half-maximal inhibitory concentration: 1660 nM
Beside the measured number, compound 4's estimate is 1.0-fold (0.02 log units) below it, within the range that was stated.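

In this assay, putting nitro in place of amino on an aromatic carbon of the core of compound 3 gave a 2.7-fold higher number from compound 3 to compound 4 (0.44 log units; beyond the scatter), a modest step that leaves the nitro compound the weaker of the pair. Set beside the earlier step, the same change carried over from one core to the other with no difference in size that can be told apart: the same change on two cores in this assay, a 2.7-fold higher number (0.43 log units; beyond the scatter) from compound 1 to compound 2 and a 2.7-fold higher number (0.44 log units; beyond the scatter) from compound 3 to compound 4, 1.0-fold (0.01 log units) apart, within the scatter of two such steps This shows that, within this assay and for these two matched pairs, the step kept its direction and its size across the two cores, but it rests on only two pairs, so it does not establish a rule for any further core in the series, and the numbers themselves do not say what in the change produces the step.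

The compounds shown hold only amino and nitro at this carbon, so it remains open how a hydroxyl group, a fluorine atom or an acetamide there would compare with either. On these data alone, it also remains open whether the step would keep its size on a core with the methoxy groups of this ring replaced, for instance by ethoxy groups, or in any other cell line.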